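This account rests on a few compounds, and the source may have more. Where it says the series, first, only, none or still open, it means among the compounds named here.

Working notes on a small set of compounds sharing one core, all tested in an ADME assay on Huh-7 cells (Homo sapiens) for cytotoxicity; a lower number here means a stronger inhibitor of growth, a higher number a weaker inhibitor of growth.

Compound 1, `COc1cc2c(=O)c(C(=O)c3ccc(C)cc3)cn(CCCc3ccccc3)c2cc1OC`, carries a 3-phenylpropyl group on the ring nitrogen and a substituted aroyl group on the core. In this assay compound 1 gives "not active" (no number reported), so no single number stands for it; it can only be placed as a weak inhibitor of growth, without a figure for how weak.

Compound 2, `COc1cc2c(=O)c(C(=O)OCc3cccc(C)c3)cn(Cc3ccc(C(F)(F)F)cc3F)c2cc1OC`, differs from compound 1 in several places at once, so its value cannot be tied to any one change. In this assay compound 2 gives 7300 nM.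

Compound 3, `COc1cc2c(=O)c(C(=O)c3ccc(C)cc3)cn(Cc3ccccc3)c2cc1OC`, is the unmeasured member. The change from compound 1 is phenyl in place of phenethyl on a saturated chain carbon bound to an aromatic nitrogen. Going by the values given here, no measured pair shows this change, so its size in this assay is unknown; with compound 1 giving no number, the expectation is that compound 3 stays in the same weak region, with no step beyond the usual scatter and a fair chance that again no number is reported. On that basis compound 3 is estimated at 40000 nM, in a range from 10000 nM to 120000 nM.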

Compound 3, concentration for 50% growth inhibition: "not active" (no number reported)
Nothing numeric was reported for compound 3; the estimate stays without a comparison.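

No step can be read between compound 1 and compound 3: in this assay compound 1 gives "not active" (no number reported) and compound 3 gives "not active" (no number reported), so neither has a number. No supporting data bear on this result. The compounds shown leave open how far the change from 3-phenylpropyl to benzyl shifts growth inhibition.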